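Methoxy added to the benzyl ring of compound 2

A few compounds are considered here, and "the series" means these few. Any claim that something is new, unique, unknown or untested is made for them only; others in the source may bear on it.

The series rests on a shared sulfonamide core, shown in compound 1 `O=S(=O)(NCCCCNCc1ccc(Br)cc1)c1cc(C(F)(F)F)cc(C(F)(F)F)c1` and compound 2 `O=S(=O)(NCCCNCc1ccccc1)c1cc(C(F)(F)F)cc(C(F)(F)F)c1`. In a functional assay on MCF7 cells (Homo sapiens) for inhibition, read by MTT assay, with a stated time of 72 h (on this read-out lower numbers stand for stronger inhibition of growth and higher numbers for weaker inhibition of growth), compound 1 gives 1500 nM, while compound 2 gives 3000 nM. Among the measured compounds shown here, the one step measured so far, a 2.0-fold higher number from compound 1 to compound 2 (0.30 log units; within the scatter), exchanged a substituted benzylamino group for a plain one and did not leave the scatter. For the measured compounds named here, on these two numbers compound 2 stands highest, with compound 1 its only neighbour and within the scatter of it.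

Compound 3 `COc1ccccc1CNCCCNS(=O)(=O)c1cc(C(F)(F)F)cc(C(F)(F)F)c1` is not yet measured. It differs from compound 2 by methoxy in place of hydrogen on an aromatic carbon. Going by the values given here, no measured step touches a methoxy group at all; the only step available, the one from compound 1 to compound 2, concerns the same benzyl ring and was itself small. Nothing here therefore points to a change beyond the scatter in this assay, in either direction. Compound 3 is accordingly expected to come out near compound 2, at an estimated 3000 nM within a range of 1000 nM to 9000 nM. The expected step is no change at the digits printed from compound 2 to compound 3 (within the scatter).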

Compound 3, concentration for 50% growth inhibition: 2600 nM
Compound 3: the middle estimate sits 1.2-fold (0.06 log units) above what was measured, and the stated range covers the measured number.
By their numbers in this assay, from the lowest: compounds 1, 3 and 2 (each within the scatter of the next).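

In this assay, the step of a 1.2-fold lower number from compound 2 to compound 3 (0.06 log units; within the scatter) shows that methoxy in place of hydrogen on this aromatic carbon, ortho to a large group, stays within the scatter, so adding this group to the plain benzyl ring gives no readable change in the number. The step of a 1.7-fold higher number from compound 1 to compound 3 (0.24 log units; within the scatter), which replaces the ((4-bromobenzyl)amino)methyl group with (2-methoxybenzyl)amino, also stays within the scatter, and the three compounds therefore cannot be set apart from one another on this read-out. No measurement is available that could explain this result.

As far as these compounds go, it remains open whether a hydroxyl, a nitrile, a carboxylic acid or a dimethylamino group at this position would give a step beyond the scatter, and whether methoxy on another carbon of the same ring would behave as it does here. Also open, from the compounds shown here alone, is what an amide in place of the secondary amine, or a longer chain with the same benzyl ring and the same core, would do to the number.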